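Variation of the Group on the Aromatic Nitrogen of the Shared Core

The source may report more compounds than this note shows. Statements on the series, on what has been measured and on what is new or still open speak of the compounds shown alone.

Compound 1 `CCOC(=O)c1ccc(-c2nn(C)c3ccccc23)cc1` gives 270 nM in a functional assay on cells (Platelet, Homo sapiens) for inhibition (on this read-out lower numbers stand for stronger inhibition and higher numbers for weaker inhibition), the second highest of the three numbers measured; compound 3 `CCOC(=O)c1ccc(-c2nn(Cc3ccccn3)c3ccccc23)cc1` with 290 nM lies nearest, compound 2 `CCOC(=O)c1ccc(-c2nn(Cc3ccc(F)cc3)c3ccccc23)cc1` with 190 nM furthest. Compound 4 `CCOC(=O)c1ccc(-c2nn(C(C)C)c3ccccc23)cc1` differs from compound 1 by isopropyl in place of methyl on an aromatic nitrogen. Going by the values given here, the only steps that bear on this place are those enlarging the group on the saturated chain carbon bound to the aromatic nitrogen: a 1.4-fold lower number from compound 1 to compound 2 (0.15 log units; within the scatter) and a 1.1-fold higher number from compound 1 to compound 3 (0.03 log units; within the scatter), both within the scatter. Growing the substituent on the aromatic nitrogen has thus left this assay flat, and no step beyond the scatter is expected for isopropyl. For compound 4 the estimated step is a 1.1-fold lower number from compound 1 to compound 4 (0.03 log units; within the scatter). Compound 4 is expected to give about 250 nM, within 120 nM to 550 nM.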

Compound 4, half-maximal inhibitory concentration: 650 nM
The estimate for compound 4 lay 2.6-fold (0.41 log units) below the measured number; the whole stated range lies below it.
By their numbers in this assay, from the lowest: compounds 2, 1 and 3 (each within the scatter of the next); then compound 4.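

Isopropyl on the aromatic nitrogen gives a 2.4-fold higher number from compound 1 to compound 4 (0.38 log units; beyond the scatter) and a 2.2-fold higher number from compound 3 to compound 4 (0.35 log units; beyond the scatter) and a 3.4-fold higher number from compound 2 to compound 4 (0.53 log units; beyond the scatter) in this assay so this position does respond to the group it carries. Methyl, (pyridin-2-yl)methyl and 4-fluorobenzyl stay within the scatter of each other, and among these four compounds only isopropyl, branched at the carbon bound to the aromatic nitrogen, stands apart. Nothing available here accounts for this step. Going by these compounds, whether the branch itself sets the step stays open: ethyl, cyclopropyl and tert-butyl on the aromatic nitrogen would bear on that.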